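This account rests on a few compounds, and the source may have more. Where it says the series, first, only, none or still open, it means among the compounds named here.

Going by the values given here, in a functional assay on HOS cells (Homo sapiens) for inhibition, with a stated time of 72 h (a higher number here means a weaker inhibitor, a lower number a stronger inhibitor), compound 2 `NC1CCC(Nc2nc(NCc3ccc(-c4ccco4)cc3)c3ncn(C4CCCC4)c3n2)CC1` gives 102 nM, the lower of the two numbers so far, and compound 1 `NC1CCC(Nc2nc(NCc3ccc(-c4cccc(F)c4)cc3)c3ncn(C4CCCC4)c3n2)CC1` gives 211 nM. Among the compounds with values here, the only measured step, a 2.1-fold lower number from compound 1 to compound 2 (0.32 log units; beyond the scatter), puts furan-2-yl in place of 3-fluorophenyl on an aromatic carbon, so it does not touch the site that changes next. Compound 3 `CC(C)(O)CNc1nc(NCc2ccc(-c3ccco3)cc2)c2ncn(C3CCCC3)c2n1` keeps furan-2-yl and carries 2-hydroxy-2-methylpropyl in place of 4-aminocyclohexyl on a nitrogen on an aromatic ring. Within the data shown here, no measured step covers this replacement, so only a rough expectation is possible: a higher number in this assay, by more than the modest measured step. The expected change is a 6.9-fold higher number from compound 2 to compound 3 (0.84 log units; beyond the scatter). Compound 3 is estimated at 700 nM, with an expected range of 200 nM to 2500 nM.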

Compound 3, half-maximal inhibitory concentration: 21400 nM
The estimate for compound 3 lay 31-fold (1.49 log units) below the measured number; the measured number lies above the stated range.
By their numbers in this assay, from the lowest: compound 2; then compound 1; then compound 3.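

The (4-aminocyclohexyl)amino site is far less tolerant in this assay than the earlier aryl change suggested: the replacement gives a 210-fold higher number from compound 2 to compound 3 (2.32 log units; beyond the scatter), a large step set against the modest 2.1-fold lower number from compound 1 to compound 2 (0.32 log units; beyond the scatter). The counts of hydrogen-bond donors and acceptors are unchanged across this replacement, so those counts alone do not distinguish the two groups. No available evidence explains the loss. From the compounds shown here alone, whether it follows the ring or the amine stays open: a 4-hydroxycyclohexyl group or an open-chain primary amine such as 2-amino-2-methylpropyl would separate the two.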